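The source may hold more compounds than are shown below. What is called first, only, known or untested is meant among the compounds shown, and "the series" means these compounds.

Compound 1 `O=C(c1ccc(Cl)cc1)N1CCN(c2nc(=O)c3cc(C(F)(F)F)cc([N+](=O)[O-])c3s2)CC1` carries 4-chlorophenyl on the carbonyl carbon of the shared core. In an ADME assay on Vero cells (Chlorocebus sabaeus) for cytotoxicity, read by MTT assay, with a stated time of 72 h (on this read-out higher numbers stand for lower toxicity in this test and lower numbers for higher toxicity in this test), compound 1 gives > 125000 nM, which is a limit of the assay rather than a number. Compound 2 `CCC(C)C(=O)N1CCN(c2nc(=O)c3cc(C(F)(F)F)cc([N+](=O)[O-])c3s2)CC1` carries sec-butyl on that carbonyl carbon. In this assay compound 2 gives > 125000 nM, again a limit of the assay. Compound 3 `O=C(C1CCCCC1)N1CCN(c2nc(=O)c3cc(C(F)(F)F)cc([N+](=O)[O-])c3s2)CC1` carries cyclohexyl on the carbonyl carbon, and in this assay compound 3 gives 88700 nM. Compound 1 thus stands at the limit of > 125000 nM in this assay, at which 2 of the 3 values shown sit, and only compound 3 returns a number. The step that the two limits leave unreadable from compound 1 to compound 2. The step of an at least 1.4-fold lower number from compound 1 to compound 3 (0.14 log units; that floor lies within the scatter), and the same holds for an at least 1.4-fold lower number from compound 2 to compound 3 (0.14 log units; that floor lies within the scatter). Compound 4 `CCCC(=O)N1CCN(c2nc(=O)c3cc(C(F)(F)F)cc([N+](=O)[O-])c3s2)CC1` has not been measured; it differs from compound 1 as follows: propyl in place of 4-chlorophenyl on a carbonyl carbon The steps from compound 1 to compound 2 and to compound 3 bear on this change, since both put a group without an aromatic ring in place of 4-chlorophenyl on the carbonyl carbon, and neither was readable as a move beyond the scatter. No step beyond the scatter is therefore expected in this assay, and the expected step is a number no higher from compound 1 to compound 4 (the limit leaves the size open). Compound 4 is estimated at 125000 nM, with an expected range from 60000 nM to 250000 nM.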

Compound 4, half-maximal cytotoxic concentration: > 125000 nM
Compound 4: a limit, no number; the forecaster's own chance of this, stated with the estimate: 60%; the middle value lies on the limit itself.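

Compound 4 joins compound 1 and compound 2 at a limit of the assay rather than a number in this assay: the limit of > 125000 nM in this assay, at which 3 of the 4 values shown sit. The steps that join compound 4 to compound 1 and to compound 2 have limits at both ends, and they cannot be read. For the compounds shown here, the one step that can be read is an at least 1.4-fold higher number from compound 3 to compound 4 (0.14 log units; that floor lies within the scatter), so the change from cyclohexyl to propyl has only a floor. Compound 3, at 88700 nM, is not shown to stand apart from the others beyond the scatter.

The compounds shown leave open whether any group on this carbonyl carbon moves the number beyond the scatter, since cyclohexyl alone returns a number, and that number cannot be set firmly against the limits of compound 1, compound 2 and compound 4. From the compounds shown here alone, whether a longer chain, a phenyl ring without the chlorine, or an amine in that place would return a number rather than a limit in this assay also stays open.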